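The source may report more compounds than this note shows. Statements on the series, on what has been measured and on what is new or still open speak of the compounds shown alone.

Working notes on the series.

Compound 1 `CC(=O)N(C)c1ccc2[nH]c(-c3n[nH]c4ccccc34)cc2n1` is the acetamide of the shared core; in a functional assay on HL-60 cells (Homo sapiens) for antiproliferative activity, read by MTT assay, with a stated time of 72 h (a lower number here means a stronger inhibitor, a higher number a weaker inhibitor), compound 1 gives 5110 nM. Compound 2 `CN(C(=O)c1ccccc1)c1ccc2[nH]c(-c3n[nH]c4ccccc34)cc2n1` carries a benzoyl in its place and in this assay compound 2 gives 4850 nM. Among the measured compounds shown here, the only step measured so far, a 1.1-fold lower number from compound 1 to compound 2 (0.02 log units; within the scatter), is within the scatter; so compound 2 holds the lowest of the two numbers, but nothing separates it from compound 1.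

Compound 3 `CN(C(=O)c1ccc(Cl)cc1)c1ccc2[nH]c(-c3n[nH]c4ccccc34)cc2n1` is the next member: chloro in place of hydrogen on an aromatic carbon, the carbon ring in question being that of the benzoyl, so that the benzoyl becomes a (4-chlorophenyl)carbonyl. For the measured compounds named here, no measured step touches this ring directly. Going by the values given here, the one step that bears on the region, a 1.1-fold lower number from compound 1 to compound 2 (0.02 log units; within the scatter), changed the whole group on the carbonyl carbon without moving the number beyond the scatter, and a single chloro on the outer ring is a smaller change than that. The expectation for compound 3 is therefore a step of a 1.2-fold lower number from compound 2 to compound 3 (0.06 log units; within the scatter), not beyond the scatter, in either direction. Compound 3 is estimated at 4200 nM, with a range of 1500 nM to 12000 nM in this assay.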

Compound 3, half-maximal inhibitory concentration: 450 nM
The estimate for compound 3 lay 9.3-fold (0.97 log units) above the measured number; the measured number lies below the stated range.
By their numbers in this assay, from the lowest: compound 3; then compounds 2 and 1 (each within the scatter of the next).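

In this assay, among the compounds shown here, the chloro is the first change to move the number beyond the scatter: it gives an 11-fold lower number from compound 2 to compound 3 (1.03 log units; beyond the scatter) on an aromatic carbon para to a large group, while the outer ring itself had brought no separable change, with a 1.1-fold lower number from compound 1 to compound 2 (0.02 log units; within the scatter) within the scatter. The full replacement of methyl by 4-chlorophenyl on the carbonyl carbon gives an 11-fold lower number from compound 1 to compound 3 (1.06 log units; beyond the scatter) and is of about the same size as the chloro step alone, so in these three compounds the difference appears only once the chloro is present, and compound 3 stands apart from both others with the lowest number. The compounds shown offer no measurement that explains this step.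

Going by these compounds, whether the step belongs to chloro in particular remains open, as the series holds no other group at this place, such as fluoro, methoxy, an amine or a carboxylic acid. Also open, on these data alone, is whether chloro would give a step of this size on the other carbons of the ring, or on a longer chain in place of the phenyl.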